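Tail ring variation in one amide series

This account rests on a few compounds, and the source may have more. Where it says the series, first, only, none or still open, it means among the compounds named here.

Measured so far in an assay on HEK293 cells for inhibition of N-acylethanolamine-hydrolyzing acid amidase (Rattus norvegicus), read by LC-MS, with a stated time of 30 min; on this read-out higher numbers stand for weaker inhibition and lower numbers for stronger inhibition:
- compound 1 `O=C(CCCCCCc1ccc(F)cc1)N1CCCC1`: 8000 nM
- compound 2 `Cc1ccc(-c2ccc(CCC(=O)N3CCCC3)cc2)cc1`: 33200 nM
- compound 3 `CCCc1ccc(CCCCCCC(=O)N2CCCC2)cc1`: > 100000 nM, which is a limit of this assay and not a number

Compound 2 stands highest of the two numbers in this assay; the nearest value is that of compound 1, which is lower. Compound 4 `O=C(CCc1ccc(-c2cccs2)cc1)N1CCCC1` differs from compound 2 in one place: thiophen-2-yl in place of 4-methylphenyl on an aromatic carbon.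

For the measured compounds named here, the only step computed between measured compounds is an at least 12-fold higher number from compound 1 to compound 3 (1.09 log units; beyond the scatter), which concerns a different position and different groups and so bears on the present change only loosely; it does show that a larger hydrocarbon on the aromatic ring was accompanied by a large rise, in keeping with the limit of > 100000 nM in this assay, at which 1 of the 3 values shown sits. Going by the values given here, no measured pair shares the change from compound 2 to compound 4. A step within or near the scatter is therefore expected, leaning toward a lower number, as a 1.7-fold lower number from compound 2 to compound 4 (0.22 log units; within the scatter).

For compound 4 in this assay a value of 20000 nM is estimated, within a range of 6000 nM to 70000 nM.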

Compound 4, half-maximal inhibitory concentration: > 100000 nM
Compound 4: only a limit was reported (the forecaster's own chance of this, stated with the estimate: 15%); at least 5.0-fold (0.69 log units) between middle value and limit.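

In this assay, thiophen-2-yl in place of 4-methylphenyl on this aromatic carbon gives an at least 3.0-fold higher number from compound 2 to compound 4 (0.47 log units; beyond the scatter), so the two tail rings are not interchangeable here. From the compounds shown here alone, compound 4 gives > 100000 nM, which is a limit and not a number, so the full size of the step stays unknown. This limit now recurs in the series: the limit of > 100000 nM in this assay, at which 2 of the 4 values shown sit.

No compound shown separates the five-membered ring, the sulfur and the lost methyl as the source of the step. Also open, going by these compounds, is how a plain phenyl or a carboxylic acid on the tail ring would read at this position.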